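Three Compounds at a Limit, a Fourth Still Unmeasured

A few compounds are considered here, and "the series" means these few. Any claim that something is new, unique, unknown or untested is made for them only; others in the source may bear on it.

Three compounds have been measured in an ADME assay on microsomes from liver (Canis lupus familiaris) for metabolic stability; a higher number here means that the compound lasts longer, a lower number that the compound disappears faster:

compound 1, `N#Cc1ccc(-c2nc(NCCNc3ccc([N+](=O)[O-])c(N)n3)ncc2-c2ncc[nH]2)cc1`, gives > 0.5 h, which is a limit of the assay and not a number
compound 2, `Nc1nc(NCCNc2ncc(-c3ncc[nH]3)c(-c3ccc(Cl)cc3)n2)ccc1[N+](=O)[O-]`, gives > 0.5 h, again a limit of the assay
compound 3, `Nc1nc(NCCNc2ncc(-c3ncc[nH]3)c(-c3ccc(F)cc3Br)n2)ccc1[N+](=O)[O-]`, gives > 0.5 h, again a limit of the assay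

Compound 2 therefore stands at the same limit as everything else measured here; the limit of > 0.5 h in this assay, at which 3 of the 3 values shown sit, describes exactly this situation. Because all three values are limits, the measured steps cannot be read: a step that the two limits leave unreadable from compound 1 to compound 2, a step that the two limits leave unreadable from compound 1 to compound 3 and a step that the two limits leave unreadable from compound 2 to compound 3 are all unreadable in size. They neither show a change beyond the usual scatter nor rule one out.

The compound not yet measured is compound 4, `Nc1nc(NCCNc2ncc(-c3ncc[nH]3)c(-c3cc(F)c(Cl)cc3F)n2)ccc1[N+](=O)[O-]`. It differs from compound 2 by 4-chloro-2,5-difluorophenyl in place of 4-chlorophenyl on an aromatic carbon.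

Within the data shown here, no measured step gives a readable size, so the expectation for this change rests on the pattern in the limit of > 0.5 h in this assay, at which 3 of the 3 values shown sit: every value seen sits at the limit. The step from compound 2 to compound 4 is therefore expected to be a step that the limit leaves unreadable from compound 2 to compound 4, which is to say no change that can be read. Compound 4 is estimated to give 0.8 h in this assay, with a range from 0.4 h to 1.6 h, and most likely only a limit will be reported.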

Compound 4, half-life: > 0.5 h
Compound 4 ended at the assay's limit; the forecaster's own chance of this, stated with the estimate: 80%; the middle value does not contradict the limit.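

Compound 4 joins compound 1, compound 2 and compound 3 at the same limit, so none of the steps linking compound 4 to those three can be read in size in this assay: the limit of > 0.5 h in this assay, at which 4 of the 4 values shown sit.

Going by these compounds, how long each of these four compounds actually lasts, and whether swapping the aromatic group changes that, remains open.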